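Swapping a fluoropyridine for a nitrile: effect on liver-cell toxicity

A few compounds are considered here, and "the series" means these few. Any claim that something is new, unique, unknown or untested is made for them only; others in the source may bear on it.

Measured so far:
- compound 1 `O=C1CC(c2ccc(F)cn2)CN1c1cnn2c1CN(C(=O)Nc1cc(F)c(F)c(F)c1)C(C1CC1)C2`: 38500 nM
- compound 2 `C[C@H]1Cn2ncc(N3CC(c4ccccc4)CC3=O)c2CN1C(=S)Nc1cc(F)c(F)c(F)c1`: > 2000 nM
- compound 3 `O=C1OC(c2ccc(F)cc2)CN1c1cnn2c1CN(C(=O)Nc1cc(F)c(F)c(F)c1)C(C1CC1)C2`: 3560 nM

In a toxicity assay on HepG2 2.2.15 cells (Homo sapiens) for cytotoxicity, read by CellTiter-Glo (a lower number here means that less compound is tolerated, a higher number that more compound is tolerated), compound 1 gives 38500 nM, the highest of the two actual numbers; compound 3 gives 3560 nM, a difference that lies beyond the usual scatter. The value for compound 2 is a limit of the assay, not a number (the limit of > 2000 nM in this assay, at which 1 of the 3 values shown sits). Compound 4 `N#CC1CC(=O)N(c2cnn3c2CN(C(=O)Nc2cc(F)c(F)c(F)c2)C(C2CC2)C3)C1` is not yet measured. It differs from compound 1 in one place (cyano in place of 5-fluoropyridin-2-yl on a saturated ring carbon). Among the compounds with values here, no measured pair shows this change, so there is no step to lean on. Since compound 1 already sits at the well-tolerated end, compound 4 is expected to stay there, with the step of a 1.0-fold higher number from compound 1 to compound 4 (0.02 log units; within the scatter) expected to be small or within the scatter. The estimate for compound 4 is 40000 nM, between 15000 nM and 100000 nM.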

Compound 4, half-maximal cytotoxic concentration: > 200000 nM
Compound 4: only a limit was reported (the forecaster's own chance of this, stated with the estimate: 35%); middle value at least 5.0-fold (0.69 log units) from the limit.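

In this assay compound 4 gives only a limit, not a number: the limit of > 200000 nM in this assay, at which 1 of the 4 values shown sits. Putting cyano in place of 5-fluoropyridin-2-yl on this saturated ring carbon gives an at least 5.1-fold higher number from compound 1 to compound 4 (0.71 log units; beyond the scatter). So this one position clearly changes how much compound the cells tolerate, and tolerance here does not depend on having an aromatic ring at that carbon.

On these data alone, it remains open whether losing the ring or gaining the cyano matters more: a methyl or an amine on the same carbon could separate the two. As far as these compounds go, the full size of the step also remains unknown.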